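Lysine-type open chain in place of the lactam

The source may report more compounds than this note shows. Statements on the series, on what has been measured and on what is new or still open speak of the compounds shown alone.

Two compounds of the series carry a value in a functional assay on HEK293 cells for agonist activity at Nucleotide-binding oligomerization domain-containing protein 1 (Homo sapiens), read by spectrophotometry; on this read-out lower numbers stand for an effect already at smaller amounts and higher numbers for an effect only at larger amounts of compound. Compound 1 `CCCCCCCCCCCOC(=O)[C@@H](CCC(=O)NC(CCCC(N)C(=O)O)C(=O)O)NC(=N)N` gives 0.238 nM in this assay. Compound 2 `CCCCCCCCCCCC(=O)N[C@H](CCC(=O)NC1CCCCNC1=O)C(=O)O` gives 1.73 nM in this assay, the higher of the two numbers; the gap between the two values lies beyond the usual scatter. Compound 3 `CCCCCCCCCCCC(=O)N[C@H](CCC(=O)N[C@@H](CCCCN)C(=O)O)C(=O)O` has not been measured. It differs from compound 2 by 5-amino-1-carboxypentyl in place of 2-oxoazepan-3-yl on an amide-type nitrogen. Among the compounds with values here, no step between measured compounds with this difference is known, so the expectation rests on the two values alone: compound 2, the weaker of the two with 1.73 nM, is the starting point, and a modest rise in the number, toward a somewhat weaker effect, is expected; the step from compound 2 to compound 3 is estimated at a 3.5-fold higher number from compound 2 to compound 3 (0.54 log units; beyond the scatter). For compound 3 the expected value in this assay is 6 nM, with a range from 1.5 nM to 30 nM.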

Compound 3, half-maximal effective concentration: 0.57 nM
Compound 3: the middle estimate sits 11-fold (1.02 log units) above what was measured; measured number outside the range, below it.
By their numbers in this assay, from the lowest: compound 1; then compound 3; then compound 2.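

In this assay the step is a 3.0-fold lower number from compound 2 to compound 3 (0.48 log units; beyond the scatter), a modest gain on opening the ring: 5-amino-1-carboxypentyl on the amide-type nitrogen serves at least as well as 2-oxoazepan-3-yl. For this pair, then, the seven-membered non-aromatic ring is not needed for an effect at low concentration, and the open chain gives the lower number. Nothing available explains the size or the direction of this step.

The change removes the ring and brings in a carboxylic acid, an amine and a defined stereocentre all at once, so the compounds shown do not tell which of these carries the step. Open chains keeping only the carboxylic acid or only the amine, or a shorter chain carrying both groups, would separate these contributions.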